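Replacing One Aryl Group on a Shared Core

The compounds below may be only part of what the source reports. "The series", "measured", "known", "first", "only" and "open" are said of these compounds alone.

Compound 1 `COC(=O)c1cc(-c2cccc(NC(=O)c3ccc(/C=C/C(=O)c4ccccc4OC)cc3)c2)on1` was tested in an ADME assay on Vero cells (Chlorocebus sabaeus) for cytotoxicity, read by MTT assay, with a stated time of 72 h (a lower number here means that less compound is tolerated, a higher number that more compound is tolerated), and gave only a limit, > 40 ug/mL, rather than a number. That result sits at the limit of > 40 ug/mL in this assay, at which 1 of the 2 values shown sits. Compound 2 `CCOC(=O)c1nnn(-c2cccc(NC(=O)c3ccc(/C=C/C(=O)c4ccc(Cl)cc4)cc3)c2)c1C` belongs to the same set, but for compound 2 the outcome in this assay was "not determined" (no result reported), so nothing can be said of it. Going by the values given here, because no two measured compounds differ in a single place, no measured step exists to lean on. Compound 3 `COC(=O)c1cc(-c2cccc(NC(=O)c3ccc(/C=C/C(=O)c4ccc(C)c([N+](=O)[O-])c4)cc3)c2)on1` differs from compound 1 by one change: 4-methyl-3-nitrophenyl in place of 2-methoxyphenyl on a carbonyl carbon. With compound 1 stopping at a limit in this assay, the account expects the step of a number no higher from compound 1 to compound 3 (the limit leaves the size open) to be no larger than the usual scatter, in no clear direction. For compound 3 the expected value in this assay is therefore 40 ug/mL, within a range from 20 ug/mL to 80 ug/mL.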

Compound 3, half-maximal cytotoxic concentration: > 80 ug/mL
Compound 3: a limit, no number; the forecaster's own chance of this, stated with the estimate: 55%; middle value at least 2.0-fold (0.30 log units) away from the limit.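

Compound 1 and compound 3 each gave only a limit in this assay, and the step between them cannot be read. The compounds shown leave open whether 4-methyl-3-nitrophenyl in place of 2-methoxyphenyl on a carbonyl carbon shifts the result in this assay at all.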